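From methoxycarbonyl to carboxy: the step to compound 4

A few compounds are considered here, and "the series" means these few. Any claim that something is new, unique, unknown or untested is made for them only; others in the source may bear on it.

Measured so far in a functional assay on DU-145 cells (Homo sapiens) for cytotoxicity, read by trypan blue exclusion, with a stated time of 96 h; on this read-out lower numbers stand for stronger inhibition and higher numbers for weaker inhibition:
compound 1 `COc1ccc(NS(=O)(=O)/C=C/c2c(F)c(F)c(F)c(F)c2F)cc1F`: 10000 nM
compound 2 `COc1cc(OC)c(/C=C/S(=O)(=O)Nc2ccc(OC)c(OP(=O)(O)O)c2)c(OC)c1`: 40 nM
compound 3 `COC(=O)C(C)Nc1cc(NS(=O)(=O)/C=C/c2c(OC)cc(OC)cc2OC)ccc1OC`: 100 nM

Among these three numbers, compound 3 at 100 nM is the second highest, lying above the number for compound 2 and below the number for compound 1. The next compound to consider, compound 4 `COc1cc(OC)c(/C=C/S(=O)(=O)Nc2ccc(OC)c(NC(C)C(=O)O)c2)c(OC)c1`, differs from compound 3 in one place: hydrogen in place of methyl on an oxygen next to a carbonyl group. Cut one bond further out, this reads methoxycarbonyl to carboxy, or 1-(methoxycarbonyl)ethyl to 1-carboxyethyl.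

Within the data shown here, no measured pair tests this change directly. Among the measured compounds shown here, compound 1 differs from the others in more than one place, so it offers no step to compare. For the measured compounds named here, the only measured step is a different replacement, on an aromatic carbon: a 2.5-fold higher number from compound 2 to compound 3 (0.40 log units; beyond the scatter). That modest step from a single pair gives a rough guide to size and none to direction. On that basis, the expected result in this assay is no shift beyond the scatter, with the estimate being a 1.2-fold higher number from compound 3 to compound 4 (0.08 log units; within the scatter). Compound 4 is estimated at 120 nM, with an expected range of 30 nM to 500 nM.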

Compound 4, half-maximal inhibitory concentration: 40 nM
Compound 4: middle estimate off by 3.0-fold (0.48 log units), on the high side; low and high end bracket the measured number.
By their numbers in this assay, from the lowest: compounds 2 and 4 (each within the scatter of the next); then compound 3; then compound 1.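

In this assay, among these compounds, the methyl on the oxygen of the ester is not a silent detail: removing it gives a 2.5-fold lower number from compound 3 to compound 4 (0.40 log units; beyond the scatter) and is the first direct reading of methoxycarbonyl to carboxy at this position, though it rests on a single pair. It also changes how the side chain compares with the group of 5 heavy atoms on the aromatic carbon, since the ester-bearing compound had given a 2.5-fold higher number from compound 2 to compound 3 (0.40 log units; beyond the scatter) while the carboxy-bearing one gives no change at the digits printed from compound 2 to compound 4 (within the scatter) and so leaves no gap beyond the scatter. Nothing in the data accounts for either step.

The compounds shown leave open whether this step is specific to methyl or would also appear with an ethyl ester, a primary amide or a hydroxamic acid in place of the methoxycarbonyl group, and whether a longer chain carrying the carboxy group would read the same as 1-carboxyethyl. Among the compounds shown here, they also leave open whether the same change would give a step of this size on any core other than the one shared by these compounds, or in any other cell line.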